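This account rests on a few compounds, and the source may have more. Where it says the series, first, only, none or still open, it means among the compounds named here.

Measured in an assay on CHO cells for displacement of a labelled ligand from prostaglandin D2 receptor 2 (Homo sapiens), read by scintillation counting; on this read-out lower numbers stand for stronger inhibition and higher numbers for weaker inhibition:
compound 1 `CN(C)S(=O)(=O)c1ccc(F)c(C#Cc2cc(Cl)ccc2OCC(=O)O)c1`: 3.1 nM
compound 2 `COCCN(C)S(=O)(=O)c1ccc(C)c(C#Cc2cc(Cl)ccc2OCC(=O)O)c1`: 4.1 nM

Compound 1 gives the smaller of the two numbers in this assay, but its gap to compound 2 lies inside the scatter, so the two are not separable. Compound 3 `O=C(O)COc1ccc(Cl)cc1C#Cc1cc(CO)ccc1F` is not yet measured; it differs from compound 1 by hydroxymethyl in place of dimethylsulfamoyl on an aromatic carbon. For the measured compounds named here, no measured pair isolates this change. The dimethylsulfamoyl is present in both measured compounds, so its loss is expected to cost potency, with a step from compound 1 to compound 3 of about a 4.8-fold higher number from compound 1 to compound 3 (0.68 log units; beyond the scatter). Compound 3 is therefore expected near 15 nM, within 5 nM to 60 nM.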

Compound 3, inhibition constant: 73 nM
Estimate against measurement, compound 3: 4.9-fold (0.69 log units) below; measured number outside the range, above it.
By their numbers in this assay, from the lowest: compounds 1 and 2 (each within the scatter of the next); then compound 3.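

In this assay, hydroxymethyl in place of dimethylsulfamoyl on this aromatic carbon, para to the fluoro group, gives a 24-fold higher number from compound 1 to compound 3 (1.37 log units; beyond the scatter) and shows that potency depends strongly on the group held here. Compound 1 and compound 2 both carry a sulfonamide at this place, so neither could show this. No measurement shown here accounts for the size of this step.

The compounds shown leave open whether the step reflects losing the dimethylsulfamoyl or introducing the hydroxymethyl. They also leave open how a methyl sulfone, a primary carboxamide or an aminomethyl group on this carbon would compare.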